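The compounds below may be only part of what the source reports. "The series", "measured", "known", "first", "only" and "open" are said of these compounds alone.

Compound 1 `CCCCc1ccc(-c2cc(N3CCC(CNS(N)(=O)=O)CC3)ncn2)cc1` gives 15200 nM in a functional assay on HT-29 cells (Homo sapiens) for antiproliferative activity, read by sulforhodamine B assay, with a stated time of 48 h; on this read-out lower numbers stand for stronger inhibition of growth and higher numbers for weaker inhibition of growth. Compound 2 `COc1ccc(-c2cc(N3CCC(CNS(N)(=O)=O)CC3)ncn2)cc1` reaches only the assay limit of > 100000 nM in this assay, so compound 2 stands at the limit of > 100000 nM in this assay, at which 1 of the 2 values shown sits, and no number is known for it. Among the compounds with values here, the single measured step, an at least 6.5-fold higher number from compound 1 to compound 2 (0.81 log units; beyond the scatter), is the only one that bears on compound 3 `NS(=O)(=O)NCC1CCN(c2cc(-c3ccc(C(F)(F)F)cc3)ncn2)CC1`, which differs from compound 2 by trifluoromethyl in place of methoxy on an aromatic carbon. The expected step of an at least 3.3-fold lower number from compound 2 to compound 3 (0.52 log units; beyond the scatter) rests on a limit for compound 2 and is loosely founded, pointing toward stronger inhibition. The estimate for compound 3 is 30000 nM, between 8000 nM and 150000 nM.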

Compound 3, concentration for 50% growth inhibition: 29100 nM
For compound 3 the middle estimate is 1.0-fold (0.01 log units) above the measured one; low and high end bracket the measured number.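

At this position, para to a large group, trifluoromethyl in place of methoxy gives an at least 3.4-fold lower number from compound 2 to compound 3 (0.53 log units; beyond the scatter) in this assay. Trifluoromethyl in place of butyl gives a 1.9-fold higher number from compound 1 to compound 3 (0.28 log units; within the scatter), so these two groups are not told apart here, and methoxy alone stands apart among the three. The value of compound 2 is a limit of the assay and not a number: the limit of > 100000 nM in this assay, at which 1 of the 3 values shown sits.

Open, on these data alone, is how an amine, a carboxylic acid or a chain longer than butyl would read at this position. Also open, as far as these compounds go, is whether any group here gives clearly stronger inhibition of growth than butyl and trifluoromethyl.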